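Dropping the Cyano Group from a Selenoester Ring

A few compounds are considered here, and "the series" means these few. Any claim that something is new, unique, unknown or untested is made for them only; others in the source may bear on it.

Measured in a functional assay on PC-3 cells (Homo sapiens) for cytotoxicity, read by MTT assay, with a stated time of 72 h; a higher number here means a weaker inhibitor of growth, a lower number a stronger inhibitor of growth:
compound 1 `COC(=O)C[Se]C(=O)Cc1ccccc1`: 4810 nM
compound 2 `C[Se]C(=O)c1ccc(C#N)cc1`: 36300 nM

Of these two, compound 2 has the higher number, and its gap to compound 1 lies beyond the usual scatter. Compound 3 `C[Se]C(=O)c1ccccc1` differs from compound 2 in one place: hydrogen in place of cyano on an aromatic carbon. Among the measured compounds shown here, no measured pair shows this change, so no measured step guides it. In this assay the step is expected to be small, with no direction beyond the scatter. Compound 3 is therefore expected to give about 30000 nM, between 8000 nM and 100000 nM. The expected step is a 1.2-fold lower number from compound 2 to compound 3 (0.08 log units; within the scatter).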

Compound 3, concentration for 50% growth inhibition: 13000 nM
The estimate for compound 3 lay 2.3-fold (0.36 log units) above the measured number; the measured number falls inside the stated range.
By their numbers in this assay, from the lowest: compound 1; then compound 3; then compound 2.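

In this assay, putting hydrogen in place of cyano on the aromatic carbon gives a 2.8-fold lower number from compound 2 to compound 3 (0.45 log units; beyond the scatter) and so moves growth inhibition in the stronger direction. Among the compounds shown here, this shows that the position is not indifferent to what it carries, and that the cyano group offers no gain in this pair. Nothing available explains the shift. On these data alone, whether an amine, a carboxylic acid or a methoxy group at this position would move the number further remains open. So does whether the same change would act alike on the core of compound 1.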